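The compounds below may be only part of what the source reports. "The series", "measured", "known", "first", "only" and "open" are said of these compounds alone.

Compound 1, `O=C1/C(=C/c2ccccc2F)CN(Cc2cn(Cc3ccccc3F)nn2)C/C1=C\c1ccccc1F`: 10600 nM
Compound 2, `Cc1ccc(/C=C2\CN(Cc3cn(Cc4ccc(F)cc4)nn3)C/C(=C\c3ccc(C)cc3)C2=O)cc1`: 49700 nM

Both compounds were tested in a functional assay on DU-145 cells (Homo sapiens) for cytotoxicity, read by MTT assay, with a stated time of 24 h; a higher number here means a weaker inhibitor, a lower number a stronger inhibitor. Among the two numbers, compound 2 stands highest, and its nearest neighbour is compound 1, whose lower number lies beyond the usual scatter of repeated measurements, so compound 1 is the stronger of the two.

Compound 3 `Cc1ccc(/C=C2\CN(Cc3cn(Cc4ccccc4Cl)nn3)C/C(=C\c3ccc(C)cc3)C2=O)cc1` has not yet been measured. It differs from compound 2 in one place: 2-chlorophenyl in place of 4-fluorophenyl on a saturated chain carbon bound to an aromatic nitrogen. Going by the values given here, no pair of measured compounds differing in a single place is available, so there is no measured step of this kind to lean on. The change swaps one halogen-bearing phenyl for another on the same saturated chain carbon, and in this assay only a small move is expected, probably toward a slightly lower number, a step described by the estimate a 1.4-fold lower number from compound 2 to compound 3 (0.15 log units; within the scatter). For compound 3 the expected value is 35000 nM, within a range from 12000 nM to 100000 nM.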

Compound 3, half-maximal inhibitory concentration: 10500 nM
Estimate against measurement, compound 3: 3.3-fold (0.52 log units) above, outside the stated range (below it).
By their numbers in this assay, from the lowest: compounds 3 and 1 (each within the scatter of the next); then compound 2.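

Going by these compounds alone, the swap gives the first measured single-place step: in this assay, putting 2-chlorophenyl in place of 4-fluorophenyl on a saturated chain carbon bound to an aromatic nitrogen gives a 4.7-fold lower number from compound 2 to compound 3 (0.68 log units; beyond the scatter). With the rest of compound 2 unchanged, this exchange of one halogen-bearing phenyl for another, each with the same count of heavy atoms, moves the number beyond the usual scatter, so the choice of group at this place matters in this assay. Nothing measured here accounts for the shift.

The step changes both the halogen and the way it is named on the ring, and the compounds shown leave open which of the two matters; a 4-chlorophenyl at this place would help separate them. Also open, as far as these compounds go, is how a group without halogen, such as a plain phenyl or a methoxyphenyl, would read here.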